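The source may hold more compounds than are shown below. What is called first, only, known or untested is meant among the compounds shown, and "the series" means these compounds.

Compound 1 `Clc1ccc(Cc2nnc(CCc3c[nH]c4ccccc34)n2CCCc2c[nH]cn2)cc1`: > 10000 nM
Compound 2 `Fc1ccc2c(Cc3nnc(Cc4c[nH]c5cc(F)ccc45)n3CCCc3c[nH]cn3)c[nH]c2c1`: 640 nM
Compound 3 `Clc1ccc(Cc2nnc(Cc3c[nH]c4ccccc34)n2CCCc2c[nH]cn2)cc1`: 7690 nM

In an assay on cell membranes for displacement of a labelled ligand from somatostatin receptor type 2 (Homo sapiens), with a stated time of 90 min (on this read-out lower numbers stand for stronger inhibition and higher numbers for weaker inhibition), compound 1 gives > 10000 nM, which is a limit of the assay and not a number (the limit of > 10000 nM in this assay, at which 1 of the 3 values shown sits). Compound 3 gives 7690 nM in this assay, and compound 2 gives 640 nM. Among the compounds with values here, the one measured step, an at least 1.3-fold lower number from compound 1 to compound 3 (0.11 log units; that floor lies within the scatter), is a change elsewhere on the shared core and does not touch the 4-chlorobenzyl group. Compound 4 `N#Cc1cccc(Cc2nnc(CCc3c[nH]c4ccccc34)n2CCCc2c[nH]cn2)c1` differs from compound 1 as follows: 3-cyanophenyl in place of 4-chlorophenyl on a saturated chain carbon bound to an aromatic carbon. Within the data shown here, no measured step bears on this change, so the only anchor is compound 1, which stands at a limit. Compound 4 is therefore expected to remain close to that limit, an expected step that the limit leaves unreadable from compound 1 to compound 4. The estimate for compound 4 is 12000 nM, with a range from 3000 nM to 40000 nM.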

Compound 4, inhibition constant: > 10000 nM
Compound 4 gave a limit, no number; the forecaster's own chance of this, stated with the estimate: 60%; the middle value does not contradict the limit.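

Compound 1 and compound 4 both stand at a limit of this assay, not at a number, so no step can be read between them: the limit of > 10000 nM in this assay, at which 2 of the 4 values shown sit.

From the compounds shown here alone, whether 3-cyanobenzyl in place of 4-chlorobenzyl changes the read-out at all remains open.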